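The compounds below may be only part of what the source reports. "The series", "measured", "known", "first", "only" and "open" are said of these compounds alone.

The measured compounds:

compound 1, `COc1cc(Cl)nc2n/c(=N/C(=O)c3c(-c4ccc(Cl)cc4Cl)noc3C)sn12`: 72.8%
compound 2, `COc1cc(C)nc(NC(=S)NC(=O)c2c(-c3ccc(Cl)cc3Cl)noc2C)n1`: 60.2%
compound 3, `Cc1onc(-c2ccc(Cl)cc2Cl)c1C(=O)/N=c1/nc2nc(Cl)cc(C)n2s1`: 68.1%

In a functional assay on the whole organism for inhibition, with Digitaria ciliaris as the target, with a stated time of 72 h, tested at 100 mg/L (on this read-out higher numbers stand for more inhibition of growth at the one concentration tested and lower numbers for less inhibition of growth), compound 1 gives 72.8%, the highest of the three numbers, although compound 3 with 68.1% lies within the scatter of it, while compound 2 with 60.2% lies beyond it. Compound 4, `COc1cc(OC)n2s/c(=N\C(=O)c3c(-c4ccc(Cl)cc4Cl)noc3C)nc2n1`, has not been measured. It differs from compound 1 in one place: methoxy in place of chloro on an aromatic carbon. Among the measured compounds shown here, the only measured step on this core, a number 4.7 percentage points lower from compound 1 to compound 3 (within the scatter), changes a different group and stays within the scatter. For the measured compounds named here, no measured step exchanges chloro for methoxy, so the expectation rests on that one small step alone: a change of a number 2.8 percentage points lower from compound 1 to compound 4 (within the scatter) is expected, not beyond the scatter. Compound 4 is therefore estimated at 70%, within 55% to 85%.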

Compound 4, percent growth inhibition at one concentration: 85.3%
Compound 4: middle estimate off by 15.3 percentage points, on the low side, and the stated range ends below it.
By their numbers in this assay, from the lowest: compounds 2, 3 and 1 (each within the scatter of the next, the first and the last beyond it); then compound 4.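

Methoxy in place of chloro on this aromatic carbon gives a number 12.5 percentage points higher from compound 1 to compound 4 (beyond the scatter) in this assay and is the first step on this core to lie beyond the scatter. Among the compounds shown here, the only earlier step on the core, a number 4.7 percentage points lower from compound 1 to compound 3 (within the scatter), stayed within it, so the group at this position can clearly shift growth inhibition. Nothing available here explains the rise. From the compounds shown here alone, whether an amine or an ethoxy group on this carbon would match methoxy remains open. So does whether the same exchange would raise the number on the core of compound 3.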